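A few compounds are considered here, and "the series" means these few. Any claim that something is new, unique, unknown or untested is made for them only; others in the source may bear on it.

Three compounds built on a shared core differ only at one aromatic carbon, and all three belong to a functional assay on HO8910 cells (Homo sapiens) for inhibition, read by MTT assay, with a stated time of 24 h, tested at 0.1 ug/mL; a lower number here means less inhibition of growth, a higher number more inhibition of growth at the concentration tested. Compound 1 `O=C(CCCCC(S)CCS)Nc1ccccc1`, with no added group at that carbon, gives 7.37%, a modest figure for growth inhibition. Compound 2 `COc1ccc(NC(=O)CCCCC(S)CCS)cc1`, which carries methoxy there, is recorded as "not active" (no number reported). It therefore has no number of its own, and the size of its gap to compound 1 cannot be stated.

Compound 3 `O=C(CCCCC(S)CCS)Nc1ccc([N+](=O)[O-])cc1` has yet to be measured. The change is nitro in place of methoxy on an aromatic carbon, para to a large group. For the measured compounds named here, no measured pair in this small set shows what such a swap does, so the data offer no firm lead on direction. With compound 1 at 7.37% as the only numerical anchor, the expected step in this assay is none beyond the usual scatter, and another report of no activity would be no surprise. The estimated value for compound 3 is 8%, with an expected range from 0% to 20%.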

Compound 3, percent growth inhibition at one concentration: "not active" (no number reported)
Compound 3 has no reported number here; no gap can be computed for the estimate.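

In this assay, for the compounds shown here, compound 2 and compound 3 are both recorded as not active, with no number, so no step between them can be read. Nothing in the available data bears on this result. Left open is whether compound 1 at 7.37% truly differs in growth inhibition from compound 2 and compound 3.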